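This account rests on a few compounds, and the source may have more. Where it says the series, first, only, none or still open, it means among the compounds named here.

Measured compounds:
compound 1, `Cc1ccc(S(=O)(=O)NCc2ccc(CNC(=O)c3ccc(F)cc3)cc2)cc1`, gives 1 nM
compound 2, `Cc1cccc(C(=O)NCc2ccc(CNS(=O)(=O)c3ccccc3)cc2)c1`, gives 1000 nM
compound 3, `O=C(NCc1ccc(CNS(=O)(=O)c2ccccc2)cc1)c1ccccc1`, gives 1 nM

These three compounds share one core and were tested in an assay on MDA-MB-231 cells for binding affinity to C-X-C chemokine receptor type 4 (Homo sapiens), read by immunofluorescence and microscopy, with stated times of 10 min and 30 min; on this read-out lower numbers stand for an effect already at smaller amounts and higher numbers for an effect only at larger amounts of compound. Compound 1 stands level with compound 3 at the digits shown, and together they carry the lowest numbers of the three, while compound 2 sits far higher. Within the data shown here, the single step between measured compounds that differ in one place is the one from compound 2 to compound 3: a 1000-fold lower number from compound 2 to compound 3 (3.00 log units; beyond the scatter). Here a methyl on an aromatic carbon of the carbonyl-bearing ring is exchanged for hydrogen, and the number falls dramatically.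

Compound 4, `Cc1ccc(S(=O)(=O)NCc2ccc(CNC(=O)c3ccccc3C)cc2)cc1`, has not yet been measured. It differs from compound 1 in one place: 2-methylphenyl in place of 4-fluorophenyl on a carbonyl carbon. The change therefore brings a methyl onto the carbonyl-bearing ring and removes the fluorine. The step from compound 2 to compound 3 bears on this, since it shows that a methyl on that same ring, though at a different place, went with a much higher number. Among the measured compounds shown here, no measured pair tells what removing the fluorine does. A sizeable rise is therefore expected for compound 4, with the step of a 100-fold higher number from compound 1 to compound 4 (2.00 log units; beyond the scatter) anticipated, though it may be smaller than the methyl step seen before. Compound 4 is estimated at 100 nM, within a range from 3 nM to 3000 nM.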

Compound 4, effective concentration (reported as EC, without a stated level of effect): 100 nM
The estimate for compound 4 equals the measured number at the digits printed; low and high end bracket the measured number.
By their numbers in this assay, from the lowest: compounds 1 and 3 (each within the scatter of the next); then compound 4; then compound 2.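

In this assay, placing 2-methylphenyl instead of 4-fluorophenyl on the carbonyl carbon gives a 100-fold higher number from compound 1 to compound 4 (2.00 log units; beyond the scatter), so this part of the molecule responds strongly to a change in the group on its aromatic ring. Until now, the link between a methyl on the carbonyl-bearing ring and a much higher number rested on one pair, a 1000-fold lower number from compound 2 to compound 3 (3.00 log units; beyond the scatter), and it now appears in a second pair built on a differently substituted version of the shared core. The two exchanged groups have the same count of heavy atoms and of hydrogen-bond donors and acceptors, and each holds one six-membered aromatic ring, yet nothing measured here explains the size of the step.

The step combines gaining a methyl with losing a fluorine, so their separate contributions remain unresolved, and a plain phenyl or a 4-methylphenyl on the same carbonyl carbon of the core of compound 1 would help to pull them apart. Also open, on these data alone, is how this assay would respond to a methoxy group, an amine or a carboxylic acid on that ring.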